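The compounds below may be only part of what the source reports. "The series", "measured", "known", "first", "only" and "open" are said of these compounds alone.

Measured in an ADME assay on liver (Rattus norvegicus) for metabolic stability, using microsomes; a higher number here means that the compound lasts longer, a lower number that the compound disappears faster:
- compound 1 `CN1Cc2cc(ccc2S(=O)(=O)C2CC2)NC(=O)CCc2cc(ccc2OCC2CC2)[C@@H](Nc2ccc3c(N)ncc(F)c3c2)C1=O`: 0.383 h
- compound 2 `CN1CCc2cccc(c2)[C@@H](Nc2ccc3c(N)ncc(F)c3c2)C(=O)N(C)Cc2cc(ccc2S(=O)(=O)C2CC2)NC1=O`: 0.1 h
- compound 3 `COc1c(F)cc2cc1CCC(=O)Nc1ccc(S(=O)(=O)C3CC3)c(c1)CN(C)C(=O)[C@@H]2Nc1ccc2c(N)ncc(F)c2c1`: 0.133 h

Compound 1 stands highest of the three in this assay. Its lead over both compound 3 and compound 2 lies beyond the scatter, and its position is the reference point for the next compound.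

Compound 4 `CN1Cc2cc(ccc2S(=O)(=O)C2CC2)NC(=O)CCc2cc(ccc2OCC(F)F)[C@@H](Nc2ccc3c(N)ncc(F)c3c2)C1=O` keeps the rest of compound 1 and changes one group: difluoromethyl in place of cyclopropyl on a saturated chain carbon bound to an oxygen on an aromatic ring. Cut one bond further out, this reads cyclopropylmethoxy to 2,2-difluoroethoxy.

Within the data shown here, no pair of measured compounds differs in one place only, so the series offers no direct precedent for this change. A modest upward step is expected, possibly no larger than the scatter, and this rests on the structural change alone. The estimated step is a 1.6-fold higher number from compound 1 to compound 4 (0.19 log units; within the scatter). Compound 4 is expected at 0.6 h, with an estimated range of 0.3 h to 1.2 h.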

Compound 4, half-life: 1.07 h
The estimate for compound 4 lay 1.8-fold (0.25 log units) below the measured number; low and high end bracket the measured number.
By their numbers in this assay, from the lowest: compounds 2 and 3 (each within the scatter of the next); then compound 1; then compound 4.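

In this assay, among these compounds, the change from cyclopropylmethoxy to 2,2-difluoroethoxy gives a 2.8-fold higher number from compound 1 to compound 4 (0.45 log units; beyond the scatter) and is the first step read with the rest of the structure held constant. It shows that the group on this saturated chain carbon bound to an oxygen on an aromatic ring can shift the read-out beyond the scatter, with the heavy-atom count of the exchanged group unchanged while its three-membered ring is lost and two fluorines enter. No measurement at hand accounts for this step, so it stands as an observation on this one pair.

A plain ethoxy or a cyclobutylmethoxy at this position would be needed to separate loss of the ring from entry of fluorine, and a 2,2,2-trifluoroethoxy would test whether further fluorine extends the step. On these data alone, whether the step holds on any other core remains open.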